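The source may report more compounds than this note shows. Statements on the series, on what has been measured and on what is new or still open speak of the compounds shown alone.

Of the compounds shown here, three sharing one core have been measured so far in an ADME assay on HUVEC cells (Homo sapiens) for cytotoxicity, read by MTT assay, with a stated time of 24 h (on this read-out higher numbers stand for lower toxicity in this test and lower numbers for higher toxicity in this test), and give closely similar results. Compound 1 (`Fc1ccccc1/C=C/c1nnc(-c2ccc3c(c2)OCCO3)o1`) gives 402000 nM in that measurement. Compound 2 (`Clc1ccccc1/C=C/c1nnc(-c2ccc3c(c2)OCCO3)o1`) gives 368000 nM and compound 3 (`Fc1cccc(/C=C/c2nnc(-c3ccc4c(c3)OCCO4)o2)c1`) gives 295000 nM on the same scale. Compound 3 thus cannot be told apart from the other two, as its gaps to both lie within the usual scatter of repeated measurements.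

Compound 4 (`Clc1ccc(/C=C/c2nnc(-c3ccc4c(c3)OCCO4)o2)cc1`) differs from compound 3 in one place (4-chlorophenyl in place of 3-fluorophenyl on a double-bonded chain carbon bound to a double-bonded chain carbon), with 4-chlorophenyl in place of 3-fluorophenyl on a double-bonded chain carbon bound to a double-bonded chain carbon. Among the compounds with values here, three measured steps bear on this change. Putting chloro in place of fluoro on an aromatic carbon gave only a small shift (a 1.1-fold lower number from compound 1 to compound 2 (0.04 log units; within the scatter)). Exchanges of the aromatic group on the same chain carbon were also small (a 1.4-fold lower number from compound 1 to compound 3 (0.13 log units; within the scatter); a 1.2-fold lower number from compound 2 to compound 3 (0.10 log units; within the scatter)). Within the data shown here, no measured compound carries a 4-chlorophenyl group, so that exact group remains untested.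

On this evidence, no step beyond the scatter is expected in this assay for this change. The estimated step is small (a 1.1-fold higher number from compound 3 to compound 4 (0.05 log units; within the scatter)). For compound 4 the expected value is 330000 nM with an estimated range from 180000 nM to 600000 nM on this scale.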

Compound 4, half-maximal cytotoxic concentration: 312000 nM
Beside the measured number, compound 4's estimate is 1.1-fold (0.02 log units) above it; the measured number falls inside the stated range.
By their numbers in this assay, from the lowest: compounds 3, 4, 2 and 1 (each within the scatter of the next).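

Compound 4 is the first compound shown with a 4-chlorophenyl group on this chain carbon, and in this assay it cannot be told apart from any of the three earlier compounds (a 1.1-fold higher number from compound 3 to compound 4 (0.02 log units; within the scatter); a 1.2-fold lower number from compound 2 to compound 4 (0.07 log units; within the scatter); a 1.3-fold lower number from compound 1 to compound 4 (0.11 log units; within the scatter)). Within the data shown here, the four groups seen on a double-bonded chain carbon bound to a double-bonded chain carbon, namely 2-fluorophenyl, 2-chlorophenyl, 3-fluorophenyl and 4-chlorophenyl, therefore give results that all lie within the scatter of one another, so this exchange adds no measurable step to those already seen. No supporting measurement is available to explain this flat result.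

All four compounds carry a phenyl ring with a single fluoro or chloro group, so the compounds shown leave open whether a different kind of group at this position, such as an amine, a carboxylic acid or a longer chain in place of the ring, would move the number beyond the scatter. They also leave open how the 3-chlorophenyl and 4-fluorophenyl groups would behave, and whether a change elsewhere on the shared core would matter more than these exchanges.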